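The source may hold more compounds than are shown below. What is called first, only, known or untested is meant among the compounds shown, and "the series" means these compounds.

Working notes on the series, growth inhibition of K562 cells.

Three compounds carry numbers in a functional assay on K562 cells (Homo sapiens) for inhibition, read by sulforhodamine B assay, with a stated time of 48 h; a lower number here means a stronger inhibitor of growth, a higher number a weaker inhibitor of growth. Compound 1 `Nc1cc(N)c2nc(-c3ccccc3)c(Oc3ccc(F)cc3)nc2c1` gives 11000 nM. Compound 2 `COc1ccc(CNc2nc3cc(N)cc(N)c3nc2-c2ccccc2)cc1OC` gives 6030 nM, and compound 3 `CCOC(=O)[C@H](CCC(=O)O)NC(=O)c1ccc(CNc2nc3cc(N)cc(N)c3nc2-c2ccccc2)cc1` gives 8710 nM. Going by the values given here, compound 1 stands at the highest of the three numbers, but its gap to compound 3 and its gap to compound 2 both fall within the usual scatter of repeated measurements, so the three values cannot be put in order and no compound can be called stronger or weaker than another on this evidence.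

Compound 4 `COc1ccc(Sc2nc3cc(N)cc(N)c3nc2-c2ccccc2)cc1` has not yet been measured in this assay. It differs from compound 1 in one place: (4-methoxyphenyl)sulfanyl in place of 4-fluorophenoxy on an aromatic carbon. Among the compounds with values here, no pair of measured compounds differs in a single change, so no measured step shows how this kind of exchange has moved the number. The three measured values sit close together despite differing groups on the shared core, which gives no sign that a change of this kind shifts growth inhibition far.

The step from compound 1 to compound 4 in this assay is therefore expected to be small, a 1.4-fold lower number from compound 1 to compound 4 (0.14 log units; within the scatter), and may well lie within the scatter. Compound 4 is estimated at 8000 nM, within a range from 3000 nM to 22000 nM.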

Compound 4, concentration for 50% growth inhibition: 9770 nM
For compound 4 the middle estimate is 1.2-fold (0.09 log units) below the measured one, within the range that was stated.
By their numbers in this assay, from the lowest: compounds 2, 3, 4 and 1 (each within the scatter of the next).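

In this assay, the series now has its first step that can be read at a single place: with (4-methoxyphenyl)sulfanyl in place of 4-fluorophenoxy on the aromatic carbon next to the ring nitrogen, the result is a 1.1-fold lower number from compound 1 to compound 4 (0.05 log units; within the scatter). At this position, ortho to a phenyl group, the two groups cannot be told apart in this assay, even though the exchange alters both the atom linking the aryl ring to the shared core and the substituent that ring carries. Nothing measured here speaks to why the two compounds read alike.

On these data alone, it remains open whether any group at this carbon can move the number beyond the scatter, for instance a morpholine ring or a short alkyl chain in place of these aryl groups. Also open is how each half of the exchange behaves alone, the ether oxygen against the sulfide sulfur and the fluorine against the methoxy group, as only the two together are shown here.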